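Amine swap from compound 3 to compound 4

The source may hold more compounds than are shown below. What is called first, only, known or untested is meant among the compounds shown, and "the series" means these compounds.

compound 1 `CCN1CCN(Cc2cc(Nc3ncc(F)c(-c4ccc(F)cc4OC)n3)cc3c2OCC(=O)N3CC)CC1`: 142 nM
compound 2 `CCN1C(=O)COc2c(CN3CCCCC3)cc(Nc3ncc(F)c(-c4ccc(F)cc4OC)n3)cc21`: 50 nM
compound 3 `CCN(CC)Cc1cc(Nc2ncc(F)c(-c3ccc(F)cc3OC)n2)cc2c1OCC(=O)N2CC`: 26 nM

In a functional assay on MV4-11 cells (Homo sapiens) for inhibition, read by luminescence, with a stated time of 72 h (on this read-out higher numbers stand for weaker inhibition and lower numbers for stronger inhibition), compound 3 gives 26 nM. Its nearest neighbour shows a 1.9-fold lower number from compound 2 to compound 3 (0.28 log units; within the scatter), so those two values cannot be ordered. The remaining gap is clearer: a 5.5-fold lower number from compound 1 to compound 3 (0.74 log units; beyond the scatter).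

Compound 4 `CCN1C(=O)COc2c(CN(C)CCN(C)C)cc(Nc3ncc(F)c(-c4ccc(F)cc4OC)n3)cc21` carries (2-(dimethylamino)ethyl)(methyl)amino in place of diethylamino on a saturated chain carbon bound to an aromatic carbon. Within the data shown here, no measured compound carries this chain. Among the measured groups at this carbon, the 4-ethylpiperazin-1-yl of compound 1 looks closest to it, and leaving that group gave a 2.8-fold lower number from compound 1 to compound 2 (0.45 log units; beyond the scatter) as well as the larger gap above. A modest move back towards compound 1 is therefore expected in this assay, towards a higher number. The expected step is a 3.3-fold higher number from compound 3 to compound 4 (0.51 log units; beyond the scatter). The estimate for compound 4 is 85 nM, with an expected range of 30 nM to 240 nM.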

Compound 4, half-maximal inhibitory concentration: 143 nM
Estimate against measurement, compound 4: 1.7-fold (0.23 log units) below, and the stated range covers the measured number.
By their numbers in this assay, from the lowest: compounds 3 and 2 (each within the scatter of the next); then compounds 1 and 4 (each within the scatter of the next).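

In this assay, the step of a 5.5-fold higher number from compound 3 to compound 4 (0.74 log units; beyond the scatter) and the step of a 2.9-fold higher number from compound 2 to compound 4 (0.46 log units; beyond the scatter) show that an open chain at this saturated carbon can give a number as high as the ring-bearing 4-ethylpiperazin-1-yl does, so the higher number in this set of four compounds does not depend on a ring. The step of a 1.0-fold higher number from compound 1 to compound 4 (0.00 log units; within the scatter) leaves compound 1 and compound 4 impossible to order, so the (2-(dimethylamino)ethyl)(methyl)amino chain and the 4-ethylpiperazin-1-yl group cannot be told apart here. No measurement at hand gives a cause for the shift.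

Open, from the compounds shown here alone, is whether the terminal dimethylamino group matters or chain length alone does. A 2-methoxyethyl chain on the same amine nitrogen, or a morpholin-4-yl group at this carbon, would test that.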